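Methoxy for Chloro Across Two Related Pairs

This account rests on a few compounds, and the source may have more. Where it says the series, first, only, none or still open, it means among the compounds named here.

Compound 1 `O=C(Nc1cc(-c2ccccc2)[nH]n1)c1ccc(Cl)nc1` and compound 2 `COc1ccc(C(=O)Nc2cc(-c3ccccc3)[nH]n2)cn1` share one core. In a functional assay on WM 266-4 cells (Homo sapiens) for antiproliferative activity, read by MTT assay, with a stated time of 48 h (on this read-out higher numbers stand for weaker inhibition and lower numbers for stronger inhibition), compound 1 gives 6430 nM, while compound 2 gives 8480 nM. The change between them, (methoxy in place of chloro on an aromatic carbon), produced a 1.3-fold higher number from compound 1 to compound 2 (0.12 log units; within the scatter).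

Compound 3 `Cc1ccc(-c2cc(NC(=O)c3cccnc3Cl)n[nH]2)cc1` rests on a different core; the difference between the two cores is not broken down here. In this assay compound 3 gives 5350 nM. Compound 4 `COc1ncccc1C(=O)Nc1cc(-c2ccc(C)cc2)[nH]n1` arises from compound 3 by the same kind of change, (methoxy in place of chloro on an aromatic carbon); here the place is ortho to a large group, whereas in compound 1 it was para to a large group.

For compound 4 the step is expected to be a 1.3-fold higher number from compound 3 to compound 4 (0.12 log units; within the scatter), since the earlier pair showed a 1.3-fold higher number from compound 1 to compound 2 (0.12 log units; within the scatter). Compound 4 is therefore estimated at 7000 nM in this assay, with a likely span from 3500 nM to 14000 nM.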

Compound 4, half-maximal inhibitory concentration: 7760 nM
Compound 4: the middle estimate sits 1.1-fold (0.04 log units) below what was measured; measured number inside the range.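

In this assay the new pair gives a 1.5-fold higher number from compound 3 to compound 4 (0.16 log units; within the scatter), and the step from chloro to methoxy carries over from one core to the other with no difference that can be told apart: the same change on two cores in this assay, a 1.3-fold higher number (0.12 log units; within the scatter) from compound 1 to compound 2 and a 1.5-fold higher number (0.16 log units; within the scatter) from compound 3 to compound 4, 1.1-fold (0.04 log units) apart, within the scatter of two such steps.
Both steps lie within the scatter, so on these two cores the change leaves the number in the same range, whether the group sits ortho to a large group, as in compound 3 and compound 4, or elsewhere, as in compound 1 and compound 2.
This does not show that methoxy has any real effect in either direction, and two pairs make no rule for other cores.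

The compounds shown leave open whether an amine, a nitrile or a longer alkoxy chain at this place would move the number beyond the scatter. They also leave open whether the same holds in any other cell line.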